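Lengthening a hydroxyl chain on a triazole: from compound 3 to 4

A few compounds are considered here, and "the series" means these few. Any claim that something is new, unique, unknown or untested is made for them only; others in the source may bear on it.

Of the compounds shown here, three sharing one core have been tested in an ADME assay on HEK293 cells (Homo sapiens) for cytotoxicity, read by sulforhodamine B assay, with a stated time of 48 h, tested at 10 uM; on this read-out higher numbers stand for more inhibition at the one concentration tested (going by the name of the read-out) and lower numbers for less inhibition. Compound 1 `COc1nc2ccc(Br)cc2cc1C(c1ccccc1)n1cc(-c2ccc(OC(F)(F)F)cc2)nn1` gives 5.8%, compound 2 `COc1nc2ccc(Br)cc2cc1C(c1ccccc1)n1cc(CCCO)nn1` gives 27.4%, and compound 3 `COc1nc2ccc(Br)cc2cc1C(c1ccccc1)n1cc(CO)nn1` gives 11.5%. Compound 3 thus stands second highest of the three; its gap to compound 1 lies within the scatter, while the step of a number 15.9 percentage points lower from compound 2 to compound 3 (beyond the scatter) lies beyond it.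

Compound 4 `COc1nc2ccc(Br)cc2cc1C(c1ccccc1)n1cc(CCO)nn1` differs from compound 3 in one place: hydroxymethyl in place of hydroxy on a saturated chain carbon bound to an aromatic carbon. The same kind of change, read in the other direction, was seen in the step of a number 15.9 percentage points lower from compound 2 to compound 3 (beyond the scatter), where 2-hydroxyethyl gave way to hydroxy. The step of a number 21.6 percentage points higher from compound 1 to compound 2 (beyond the scatter) and the step of a number 5.7 percentage points higher from compound 1 to compound 3 (within the scatter) also touch this group. Compound 4 carries a chain between those of compound 3 and compound 2, so a modest rise from compound 3 is expected, roughly half of the drop seen between compound 2 and compound 3. For compound 4 the expected value in this assay is 18%, with a range from 8% to 30%, which means an expected step of a number 6.5 percentage points higher from compound 3 to compound 4 (within the scatter).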

Compound 4, a percentage reported as inhibition, at one concentration (the size of the read-out at that concentration, not a potency): 4.54%
Compound 4: the middle estimate sits 13.5 percentage points above what was measured; measured number below the stated range.
By their numbers in this assay, from the lowest: compounds 4, 1 and 3 (each within the scatter of the next); then compound 2.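

In this assay the hydroxyl chains on the triazole do not form a steady series: the step of a number 7 percentage points lower from compound 3 to compound 4 (within the scatter) shows that hydroxymethyl and 2-hydroxyethyl cannot be told apart, while the step of a number 22.9 percentage points lower from compound 2 to compound 4 (beyond the scatter) sets the 3-hydroxypropyl chain of compound 2 apart from the 2-hydroxyethyl chain. Swapping 4-(trifluoromethoxy)phenyl for 2-hydroxyethyl also has no readable effect, as the step of a number 1.3 percentage points lower from compound 1 to compound 4 (within the scatter) shows, so among these four compounds only compound 2 stands clear of the others. Nothing available explains why the 3-hydroxypropyl chain alone separates.

Going by these compounds, whether a longer chain such as 4-hydroxybutyl would read like compound 2 remains open. So does how an amine or a carboxylic acid in place of the hydroxy group would read on these chains.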